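The source may hold more compounds than are shown below. What is called first, only, known or untested is meant among the compounds shown, and "the series" means these compounds.

Three compounds share a core and differ in one group on an aromatic carbon: the iodo compound 1 `C/C(=N\NC(=S)Nc1ccc(I)cc1)c1ccccn1`, the fluoro compound 2 `C/C(=N\NC(=S)Nc1ccc(F)cc1)c1ccccn1` and the nitro compound 3 `C/C(=N\NC(=S)Nc1ccc([N+](=O)[O-])cc1)c1ccccn1`. In a functional assay on T98G cells (Homo sapiens) for cytotoxicity, read by MTT assay, with a stated time of 48 h (a higher number here means a weaker inhibitor, a lower number a stronger inhibitor), compound 1 gives 64 nM, compound 2 gives 17 nM and compound 3 gives 140 nM. Compound 2 therefore has the lowest number of the three and is the strongest inhibitor among them.

Compound 4 `CC(=NNC(=S)Nc1ccc(F)cc1)c1ccccn1` is compared with compound 2: the two compounds have the same atoms and bonds; at least one stereo element is drawn with a configuration in one of them and without one in the other: 1 of 1 stereo elements differ; a double bond is drawn E in compound 2 and without a configuration in compound 4. The two have the same atoms and bonds, and a double bond is drawn E in compound 2 and without a configuration in compound 4.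

The measured steps bear on this only indirectly. Each swaps a group on an aromatic carbon, as in a 3.8-fold lower number from compound 1 to compound 2 (0.58 log units; beyond the scatter), a 2.2-fold higher number from compound 1 to compound 3 (0.34 log units; beyond the scatter) and an 8.2-fold higher number from compound 2 to compound 3 (0.92 log units; beyond the scatter). Among the compounds with values here, no measured pair tests a change in how a double bond is drawn, so these modest steps set no size for this one.

Compound 4 keeps every group of compound 2, so the expectation rests on compound 2 at 17 nM. The estimated step is a 1.1-fold higher number from compound 2 to compound 4 (0.02 log units; within the scatter), which is expected to stay within the scatter, with no clear direction. For compound 4 the estimated value is 18 nM, with an expected range from 8 nM to 40 nM.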

Compound 4, half-maximal inhibitory concentration: 17 nM
The estimate for compound 4 lay 1.1-fold (0.02 log units) above the measured number; low and high end bracket the measured number.
By their numbers in this assay, from the lowest: compounds 2 and 4 (each within the scatter of the next); then compound 1; then compound 3.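

In this assay, within the data shown here, the new pair gives no change at the digits printed from compound 2 to compound 4 (within the scatter), so dropping the drawn configuration leaves the two numbers inseparable, whereas every swap of the group on the aromatic carbon among the earlier compounds moved the number beyond the scatter. This is the only pair shown that leaves that group alone and changes how a double bond is drawn, and the structures differ in nothing else: the fact that one of compounds 2 and 4 is drawn with a defined configuration and the other without, at the place where they differ. For this fluoro pair, then, the way the double bond is drawn makes no difference that this assay can detect, though the pair says nothing about the compounds carrying other groups.

From the compounds shown here alone, a drawing without a configuration does not tell whether compound 4 is the same form as compound 2, a mixture of forms or the other form, so the effect of a real switch at this double bond remains unknown. Going by these compounds, it also remains open how the number would respond if an amine or a carboxylic acid took the place of the fluoro group on the aromatic carbon.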